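Methoxy in Place of Hydrogen on Two Cores

The source may report more compounds than this note shows. Statements on the series, on what has been measured and on what is new or still open speak of the compounds shown alone.

Compound 1, `COc1ccc(/C=C/C(=O)CC(C)=O)cc1OC`: 9900 nM
Compound 2, `COc1ccc(/C=C/C(=O)CC(C)=O)cc1`: 41600 nM
Compound 3, `Cc1cc(/C=C/c2ccc(O)cc2)on1`: 58300 nM

Three compounds were measured in an ADME assay on MDCK cells (Canis lupus familiaris) for cytotoxicity, read by MTT assay, with a stated time of 72 h; on this read-out higher numbers stand for weaker inhibition and lower numbers for stronger inhibition. Compound 2 and compound 1 share a core and differ by one change, (methoxy in place of hydrogen on an aromatic carbon); this gave a 4.2-fold lower number from compound 2 to compound 1 (0.62 log units; beyond the scatter). Compound 3 has a different core, and the difference between the two cores is not broken down here. In this assay compound 3 gives 58300 nM, which lies within the scatter of the number for compound 2.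

Compound 4, `COc1cc(/C=C/c2cc(C)no2)ccc1O`, has not yet been measured in this assay. It differs from compound 3 by methoxy in place of hydrogen on an aromatic carbon. This is the same kind of change as from compound 2 to compound 1, but the place is not the same: in compound 4 the new methoxy sits ortho to a hydroxy group, in compound 1 ortho to a methoxy group. Because a 4.2-fold lower number from compound 2 to compound 1 (0.62 log units; beyond the scatter) was modest, a step of similar direction but uncertain size is expected here, a 2.3-fold lower number from compound 3 to compound 4 (0.37 log units; beyond the scatter). Compound 4 is therefore estimated at 25000 nM, expected to lie between 8000 nM and 70000 nM.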

Compound 4, half-maximal inhibitory concentration: 29800 nM
Compound 4: the middle estimate sits 1.2-fold (0.08 log units) below what was measured, within the range that was stated.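

In this assay, methoxy in place of hydrogen on an aromatic carbon gave a 2.0-fold lower number from compound 3 to compound 4 (0.29 log units; within the scatter). Set beside the earlier step on the other core, the two results cannot be told apart: the same change on two cores in this assay, a 4.2-fold lower number (0.62 log units; beyond the scatter) from compound 2 to compound 1 and a 2.0-fold lower number (0.29 log units; within the scatter) from compound 3 to compound 4, 2.1-fold (0.33 log units) apart, within the scatter of two such steps. Among the compounds shown here, this shows that the data give no sign of the core altering this change, but it does not show that the step has the same size on both cores: each core offers only one pair, only the step from compound 2 to compound 1 lies beyond the scatter, and the place of the methoxy is not the same, as in compound 4 it sits ortho to a hydroxy group.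

The compounds shown leave open whether a longer chain such as ethoxy, an amine or a carboxylic acid on the same aromatic carbon would give a step like those seen with methoxy. They also leave open how methoxy would behave at other places on the six-membered aromatic ring of compound 3.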